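The source may report more compounds than this note shows. Statements on the series, on what has been measured and on what is new or still open speak of the compounds shown alone.

Compound 1 `CNC(=O)c1cc(C(=O)N[C@H]2CC[C@H](O)CC2)n([C@@H](C)c2ccccc2)n1`: >= 180 ug/mL
Compound 2 `CNC(=O)c1cc(C(=O)N[C@H]2CC[C@H](O)CC2)c([C@@H](C)c2ccccc2)o1`: >= 184 ug/mL
Compound 3 `CNC(=O)c1cc(C(=O)NC(C)CO)n([C@@H](C)c2ccccc2)n1`: not yet measured

In a physicochemical assay for solubility (a higher number here means a more soluble compound, a lower number a less soluble compound), compound 1 gives >= 180 ug/mL, which is a limit of the assay and not a number. Compound 2 gives >= 184 ug/mL, and this is also a limit. Compound 1 therefore has no exact reading, and the two measured compounds cannot be ranked.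

Compound 3 keeps the core of compound 1 but carries 1-(hydroxymethyl)ethyl in place of 4-hydroxycyclohexyl on an amide-type nitrogen. For the measured compounds named here, no measured pair in this set shows what such a change does. The expectation is therefore no step beyond the scatter, and another limit reading seems likely. The estimated change is a step that the limit leaves unreadable from compound 1 to compound 3. For compound 3 the expected value is 190 ug/mL, with an estimated range of 130 ug/mL to 260 ug/mL.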

Compound 3, solubility: >= 132 ug/mL
Compound 3 ended at the assay's limit; the forecaster's own chance of this, stated with the estimate: 70%; the middle value lies beyond the limit too.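

In this assay compound 3 gives >= 132 ug/mL, which is a limit of the assay and not a number. Compound 1 also has only a limit, so no step can be read between compound 1 and compound 3. The compounds shown leave open whether 1-(hydroxymethyl)ethyl in place of 4-hydroxycyclohexyl changes the reading in this assay at all.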